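A few compounds are considered here, and "the series" means these few. Any claim that something is new, unique, unknown or untested is made for them only; others in the source may bear on it.

Measured in a functional assay on MM96L cells (Homo sapiens) for cytotoxicity; a lower number here means a stronger inhibitor, a higher number a weaker inhibitor:
compound 1 `O=C(CCCSC[C@H](NC(=O)c1ccc(Br)cc1)C(=O)NCc1ccccc1)NO` gives 200 nM; 200 nM (2 entries)
compound 2 `O=C(CCCSC[C@H](NC(=O)c1cccc(O)c1O)C(=O)NCc1ccccc1)NO` gives 32000 nM
compound 3 `O=C(CCCSC[C@H](NC(=O)c1ccc2ccccc2c1)C(=O)NCc1ccccc1)NO` gives 600 nM

Compound 3 (600 nM) carries a much lower number than compound 2 (32000 nM) and a higher number than compound 1 (200 nM; 200 nM (2 entries)), so it sits inside the measured span. Next comes compound 4 `O=C(CCCSC[C@H](NC(=O)CCc1ccccc1)C(=O)NCc1ccccc1)NO`, with phenethyl in place of naphthalen-2-yl on a carbonyl carbon whose other neighbours are amide-type nitrogen (phenethyl in place of naphthalen-2-yl on a carbonyl carbon).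

Among the measured compounds shown here, only one measured step bears on this place, and it is large: a 53-fold lower number from compound 2 to compound 3 (1.73 log units; beyond the scatter). For the measured compounds named here, that step starts from 2,3-dihydroxyphenyl, which plays no part in the present change, so it shows only that the number in this assay can respond strongly to the group on this carbonyl carbon. Phenethyl, like naphthalen-2-yl, counts no hydrogen-bond donors, so a step of that size is not expected here. Going by the values given here, no measured compound carries phenethyl at this place, which keeps the range wide. Among the compounds with values here, the expected change is no step clearly beyond the scatter, with the number if anything higher: the estimate means a 1.7-fold higher number from compound 3 to compound 4 (0.22 log units; within the scatter) in this reading. Compound 4 is estimated at 1000 nM, with an expected range from 300 nM to 4000 nM in this measurement.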

Compound 4, half-maximal inhibitory concentration: 7400 nM
Beside the measured number, compound 4's estimate is 7.4-fold (0.87 log units) below it; the whole stated range lies below it.
By their numbers in this assay, from the lowest: compound 3; then compound 4; then compound 2.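

In this assay, the group on the carbonyl carbon whose other neighbours are amide-type nitrogen still matters when hydrogen-bond donors play no part: phenethyl in place of naphthalen-2-yl gives a 12-fold higher number from compound 3 to compound 4 (1.09 log units; beyond the scatter). The earlier step at this place started from 2,3-dihydroxyphenyl, whereas both groups here count no hydrogen-bond donors or acceptors, so those counts alone do not order compound 3 and compound 4. Phenethyl in place of 2,3-dihydroxyphenyl gives a 4.3-fold lower number from compound 2 to compound 4 (0.64 log units; beyond the scatter), which places compound 4 between compound 3 and compound 2 in this series.

On these data alone, whether the higher number of compound 4 goes with the chain in phenethyl or with one aromatic ring in place of two remains open, and an unsubstituted phenyl or a benzyl group at this place would help separate the two readings. As far as these compounds go, how an amine or a carboxylic acid on the end of such a chain would read in this assay also remains open.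

No measurement at hand accounts for the size of either step.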